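A ring swap on the sulfonyl sulfur of compound 3

This account rests on a few compounds, and the source may have more. Where it says the series, first, only, none or still open, it means among the compounds named here.

Measured in an ADME assay on HepG2 2.2.15 cells (Homo sapiens) for cytotoxicity, read by luminescence, with a stated time of 3 days; on this read-out lower numbers stand for higher toxicity in this test and higher numbers for lower toxicity in this test:
Compound 1 `O=C(Nc1ccc(F)c(Cl)c1)c1ccc(F)c(S(=O)(=O)N2CCCCCC(O)C2)c1`: 11000 nM
Compound 2 `COC1COCCN(S(=O)(=O)c2cc(C(=O)Nc3ccc(F)c(Cl)c3)ccc2F)C1`: 8700 nM
Compound 3 `CN1CCN(S(=O)(=O)c2cc(C(=O)Nc3ccc(F)c(Cl)c3)ccc2F)CC(O)C1`: 31000 nM

Compound 3, at 31000 nM, has the highest number of the three. Compound 4 `CN1CCCN(S(=O)(=O)c2cc(C(=O)Nc3ccc(F)c(Cl)c3)ccc2F)CC1=O` carries 4-methyl-3-oxo-1,4-diazepan-1-yl in place of 6-hydroxy-4-methyl-1,4-diazepan-1-yl on a sulfonyl sulfur. Within the data shown here, no measured compound has this ring, so only other ring swaps can guide the estimate. Two were modest: a 2.8-fold higher number from compound 1 to compound 3 (0.45 log units; beyond the scatter) and a 3.6-fold higher number from compound 2 to compound 3 (0.55 log units; beyond the scatter). A third, a 1.3-fold lower number from compound 1 to compound 2 (0.10 log units; within the scatter), stayed within the scatter. With compound 3 at the top of this small set, a small move towards lower numbers is expected, no larger than those modest steps. The expected change is a 1.6-fold lower number from compound 3 to compound 4 (0.19 log units; within the scatter). Compound 4 is estimated at 20000 nM, within a range of 8000 nM to 50000 nM.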

Compound 4, half-maximal cytotoxic concentration: > 100000 nM
Compound 4 was reported as a limit; the forecaster's own chance of this, stated with the estimate: 20%; middle value at least 5.0-fold (0.69 log units) from the limit.
By their numbers in this assay, from the lowest: compounds 2 and 1 (each within the scatter of the next); then compound 3. At a limit, above all of these: compound 4.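

Compound 4 stands at a limit of the read-out, not at a number: the limit of > 100000 nM in this assay, at which 1 of the 4 values shown sits. This position on the sulfonyl sulfur therefore tolerates more change in the read-out than the earlier ring swaps showed, even with the ring size of compound 3 kept: an at least 3.2-fold higher number from compound 3 to compound 4 (0.50 log units; beyond the scatter). Against the other two rings the gap is wider: an at least 11-fold higher number from compound 2 to compound 4 (1.06 log units; beyond the scatter) and an at least 9.0-fold higher number from compound 1 to compound 4 (0.95 log units; beyond the scatter).

The compounds shown do not separate the effect of gaining the carbonyl from that of losing the hydroxy group. Going by these compounds, how a plain 4-methyl-1,4-diazepan-1-yl ring or a six-membered piperidine ring would read remains open.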